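Dropping the 4-Methoxyphenyl Group: From Compound 3 to Compound 4

The source may report more compounds than this note shows. Statements on the series, on what has been measured and on what is new or still open speak of the compounds shown alone.

Measured compounds:
- compound 1, `COc1ccc(-c2cn(C/C=C3\OC(=O)C(OCc4ccccc4)=C3OCc3ccccc3)nn2)cc1`: > 100000 nM
- compound 2, `Cc1ccc(-c2cn(C/C=C3\OC(=O)C(OCc4ccccc4)=C3OCc3ccccc3)nn2)cc1`: > 100000 nM
- compound 3, `COc1ccc(-c2cn(C[C@H](O)[C@H]3OC(=O)C(OCc4ccccc4)=C3OCc3ccccc3)nn2)cc1`: 28300 nM

In a functional assay on A549 cells (Homo sapiens) for antiproliferative activity, read by MTT assay, with a stated time of 72 h (on this read-out higher numbers stand for weaker inhibition and lower numbers for stronger inhibition), compound 1 reaches only a limit, > 100000 nM, and no number. Compound 2 likewise gives only a limit, > 100000 nM. The step that the two limits leave unreadable from compound 1 to compound 2 therefore cannot be read, since both of its ends sit at the limit of > 100000 nM in this assay, at which 2 of the 3 values shown sit. Among the compounds with values here, compound 3 is the one compound with a measured number, 28300 nM in this assay, and so it stands as the only fixed point among the three.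

Compound 4, `O=C1O[C@H]([C@@H](O)Cn2ccnn2)C(OCc2ccccc2)=C1OCc1ccccc1`, differs from compound 3 by hydrogen in place of 4-methoxyphenyl on an aromatic carbon. Within the data shown here, no measured step covers this kind of change: the one step on record, from compound 1 to compound 2, is unreadable and concerns a different part of the molecule. Compound 4 is therefore expected to be estimated near 60000 nM in this assay, between 20000 nM and 150000 nM, which means an expected step of a 2.1-fold higher number from compound 3 to compound 4 (0.33 log units; beyond the scatter) that carries a fair chance of ending at a limit rather than a number.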

Compound 4, half-maximal inhibitory concentration: > 100000 nM
Compound 4: no number, only a limit; the forecaster's own chance of this, stated with the estimate: 40%; middle value at least 1.6-fold (0.22 log units) from the limit.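

Replacing the 4-methoxyphenyl group with hydrogen, on an aromatic carbon of the five-membered aromatic ring with 3 nitrogen, gives an at least 3.5-fold higher number from compound 3 to compound 4 (0.54 log units; beyond the scatter) in this assay. Within the data shown here, the earlier compounds offered no readable step, so this is the first sign that a change at this position can move the read-out, and here it moves towards weaker inhibition. Compound 4 gives a limit and not a number, so the step is known from one side only: the limit of > 100000 nM in this assay, at which 3 of the 4 values shown sit.

The compounds shown cannot tell whether the aromatic ring or the methoxy group on it matters more, and a plain phenyl group or an aminophenyl group at this carbon would help separate the two. Also open, as far as these compounds go, is whether a small group such as methyl at this carbon would behave like hydrogen or like the 4-methoxyphenyl group.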